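Fluoro in Place of Hydrogen on the Phenyl Ring

This account rests on a few compounds, and the source may have more. Where it says the series, first, only, none or still open, it means among the compounds named here.

Compound 1, `CCCn1c(=O)[nH]c2nc(-c3ccc(S(=O)(=O)N4CCN(c5ccccc5)CC4)cc3)[nH]c2c1=O`: 364 nM
Compound 2, `CCCn1c(=O)[nH]c2nc(-c3ccc(S(=O)(=O)N4CCN(c5cccc(Cl)c5)CC4)cc3)[nH]c2c1=O`: > 1000 nM
Compound 3, `CCCn1c(=O)[nH]c2nc(-c3ccc(S(=O)(=O)N4CCN(Cc5cccc(C)c5)CC4)cc3)[nH]c2c1=O`: 795 nM

In an assay on CHO cells for displacement of a labelled ligand from adenosine receptor A1 (Homo sapiens), read by scintillation counting, with a stated time of 90 min, in the presence of a further agent that is not named here (a lower number here means a stronger inhibitor, a higher number a weaker inhibitor), compound 1 gives the lowest number of the two numbers shown. Compound 2 gives only a limit of the assay, (the limit of > 1000 nM in this assay, at which 1 of the 3 values shown sits). Compound 3 sits higher, shown by a 2.2-fold higher number from compound 1 to compound 3 (0.34 log units; beyond the scatter), and between compound 2 and compound 3 the step is an at least 1.2-fold lower number from compound 2 to compound 3 (0.09 log units; that floor lies within the scatter).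

Compound 4, `CCCn1c(=O)[nH]c2nc(-c3ccc(S(=O)(=O)N4CCN(c5ccccc5F)CC4)cc3)[nH]c2c1=O`, differs from compound 1 by fluoro in place of hydrogen on an aromatic carbon. The nearest measured step is an at least 2.7-fold higher number from compound 1 to compound 2 (0.43 log units; beyond the scatter), where a halogen also enters the phenyl ring on an amine nitrogen in the ring, though at a different place and as a larger atom. That step, together with a 2.2-fold higher number from compound 1 to compound 3 (0.34 log units; beyond the scatter), suggests that changes on this outer ring move the number upward by modest amounts. Fluoro is a smaller group than chloro, so a smaller rise is expected: the step from compound 1 to compound 4 is estimated at a 1.4-fold higher number from compound 1 to compound 4 (0.14 log units; within the scatter). Compound 4 is therefore expected to give about 500 nM, within a range of 220 nM to 1200 nM.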

Compound 4, inhibition constant: > 1000 nM
Compound 4: only a limit was reported; the forecaster's own chance of this, stated with the estimate: 20%; middle value at least 2.0-fold (0.30 log units) away from the limit.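

In this assay compound 4 is reported only as a limit: the limit of > 1000 nM in this assay, at which 2 of the 4 values shown sit. A single fluoro on an aromatic carbon, ortho to a large group, is thus enough to give an at least 2.7-fold higher number from compound 1 to compound 4 (0.43 log units; beyond the scatter), so even this one added atom on the phenyl ring of compound 1 weakens binding beyond the scatter. The comparison with the benzyl compound gives an at least 1.2-fold higher number from compound 3 to compound 4 (0.09 log units; that floor lies within the scatter), whose floor does not separate the two, and the step between the two limits cannot be read.

As far as these compounds go, how weak compound 4 really is stays unknown, since only its limit is available. Also open, from the compounds shown here alone, is whether a methoxy group or an amine at this same place would keep the number near that of compound 1, or whether fluoro elsewhere on the phenyl ring would.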